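Moving a Methoxy Group on a Cell-Growth Inhibitor

The source may report more compounds than this note shows. Statements on the series, on what has been measured and on what is new or still open speak of the compounds shown alone.

For the measured compounds named here, compound 1 `C=C(Br)C(=O)Nc1cccc(-c2cn3nc(Cc4cccc(OC)c4)sc3n2)c1` gives 2500 nM in a functional assay on HeLa cells (Homo sapiens) for inhibition, read by cell counting, with a stated time of 4 days (a higher number here means a weaker inhibitor, a lower number a stronger inhibitor), the lowest of the three numbers measured so far. Compound 2 `COc1cccc(Cc2nn3cc(-c4cccc(N)c4)nc3s2)c1` gives 24000 nM in this assay, and compound 3 `Nc1cccc(-c2cn3nc(-c4ccc(Cl)cc4)sc3n2)c1` gives 160000 nM. Going by the values given here, the only step measured between two compounds differing in one place, a 9.6-fold higher number from compound 1 to compound 2 (0.98 log units; beyond the scatter), concerns the group on the ring nitrogen, not the part of the molecule changed here. Compound 4 `C=C(Br)C(=O)Nc1cccc(-c2cn3nc(Cc4ccc(OC)cc4)sc3n2)c1` differs from compound 1 by 4-methoxyphenyl in place of 3-methoxyphenyl on a saturated chain carbon bound to an aromatic carbon. Among the compounds with values here, no measured step bears on this change, so the expectation is a step of no change at the digits printed from compound 1 to compound 4 (within the scatter), not beyond the scatter. Compound 4 is therefore estimated at 2500 nM, within a range from 800 nM to 8000 nM.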

Compound 4, half-maximal inhibitory concentration: 2300 nM
Estimate against measurement, compound 4: 1.1-fold (0.04 log units) above; the range from low to high includes it.
By their numbers in this assay, from the lowest: compounds 4 and 1 (each within the scatter of the next); then compound 2; then compound 3.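

Moving the methoxy group, with 4-methoxyphenyl in place of 3-methoxyphenyl on a saturated chain carbon, gives in this assay a 1.1-fold lower number from compound 1 to compound 4 (0.04 log units; within the scatter) and so leaves compound 1 and compound 4 indistinguishable here. For the compounds shown here, this is the first measured step at this part of the molecule, since the earlier step concerned only the group on the ring nitrogen. Nothing shown explains this result. Still open, going by these compounds, is how an amine or a carboxylic acid in place of the methoxy group would read in this assay. A longer chain joining the phenyl ring to the shared core is equally untested by the compounds shown.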